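Swapping the carbonyl substituent on compound 2

The source may hold more compounds than are shown below. What is called first, only, known or untested is meant among the compounds shown, and "the series" means these compounds.

Measured compounds:
Compound 1 `CCn1c(-c2cnc(C)nc2)nc2c(N[C@H]3CCN(C(=O)C4CCC4)C3)ncnc21` — 1.3 L/kg
Compound 2 `CCn1c(-c2ccc(C(F)(F)F)nc2)nc2c(O[C@H]3CCN(C(=O)N4CC(OC)C4)C3)ncnc21` — 0.7 L/kg
Compound 3 `CCn1c(-c2cnc(C)nc2)nc2c(N[C@H]3CCN(C(=O)[C@H]4C[C@@H](OC)C4)C3)ncnc21` — 1.5 L/kg

Three compounds sharing a core have been characterised in an ADME assay (Canis lupus familiaris, strain Beagle) for pharmacokinetics; a higher number here means that more of the compound sits outside the plasma, a lower number that more of the compound stays in the plasma. Compound 1 gives 1.3 L/kg and compound 3, which carries a methoxy in place of hydrogen on a saturated ring carbon, gives 1.5 L/kg; the step of a 1.2-fold higher number from compound 1 to compound 3 (0.06 log units; within the scatter) lies within the scatter. Compound 2 gives 0.7 L/kg, the lowest of the three numbers; its gap to compound 1 is within the scatter, while its gap to compound 3 is beyond it.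

Compound 4 `CCn1c(-c2ccc(C(F)(F)F)nc2)nc2c(O[C@H]3CCN(C(=O)C4CCOC4)C3)ncnc21` is not yet measured. It differs from compound 2 in one place: oxolan-3-yl in place of 3-methoxyazetidin-1-yl on a carbonyl carbon. Among the compounds with values here, no measured step touches a carbonyl substituent, so the only step available, a 1.2-fold higher number from compound 1 to compound 3 (0.06 log units; within the scatter), concerns a different change and bears only loosely on this one; it shows that a small alteration on a saturated ring left this assay essentially unchanged. On that basis compound 4 is expected to stay close to compound 2, with the step of a 1.1-fold higher number from compound 2 to compound 4 (0.06 log units; within the scatter) estimated to remain within the scatter. The estimate for compound 4 in this assay is 0.8 L/kg, with a range from 0.5 L/kg to 1.4 L/kg.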

Compound 4, volume of distribution: 0.9 L/kg
Compound 4: middle estimate off by 1.1-fold (0.05 log units), on the low side; the range from low to high includes it.
By their numbers in this assay, from the lowest: compounds 2, 4, 1 and 3 (each within the scatter of the next, the first and the last beyond it).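

In this assay, the carbonyl carbon now has a measured step of its own: oxolan-3-yl in place of 3-methoxyazetidin-1-yl gives a 1.3-fold higher number from compound 2 to compound 4 (0.11 log units; within the scatter). The swap exchanges a four-membered ring holding a nitrogen and a methoxy group for a five-membered ring with its oxygen in the ring, while the count of hydrogen-bond acceptors in the group stays the same, and for this pair the read-out stays within the scatter, so at this place on compound 2 the change in ring size and in ring atoms leaves no distinguishable mark on the number. Nothing available here offers an explanation of this result, and the pair alone gives none.

On these data alone, whether a group of another kind on the carbonyl carbon, such as a dimethylamino group, a carboxylic acid or an open chain like 2-methoxyethyl, would carry the number beyond the scatter remains open. The compounds shown also hold this swap in a single setting, that of compound 2, so whether it would behave the same way on the other parts of compound 1 cannot be told.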